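The source may report more compounds than this note shows. Statements on the series, on what has been measured and on what is new or still open speak of the compounds shown alone.

Series notes.

Compound 2 `Cc1[nH]cc(C)c(=O)c1O` gives -0.13 in a physicochemical assay for lipophilicity, using the shake flask method, measured as octanol-water partition; on this read-out lower numbers stand for lower lipophilicity and higher numbers for higher lipophilicity. Compound 1 `Cc1cn(C)c(C)c(O)c1=O` carries the change methyl in place of hydrogen on an aromatic nitrogen and gives -0.51 in this assay; the step is a number 0.38 log units lower from compound 2 to compound 1 (beyond the scatter). Compound 3 `COc1c[nH]cc(C)c1=O` gives -0.51 in this assay, level with compound 1 at the digits printed; the difference between the cores of compound 3 and compound 2 is not broken down here.

Compound 4 `COc1cn(C)cc(C)c1=O` is not yet measured. It differs from compound 3 by methyl in place of hydrogen on an aromatic nitrogen. Going by the values given here, this is the same kind of change as the one from compound 2 to compound 1, not the same: there the site is ortho to a methyl group and meta to a hydroxy group, here it is meta to a methoxy group; both sites are meta to a methyl group and para to a group of 1 heavy atom. The change is seen twice among the compounds shown, once measured.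

Among the compounds with values here, the expected step from compound 3 to compound 4 in this assay is a number 0.38 log units lower from compound 3 to compound 4 (beyond the scatter), resting on the one measured step of a number 0.38 log units lower from compound 2 to compound 1 (beyond the scatter). Compound 4 is therefore estimated at -0.89, between -1.3 and -0.5.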

Compound 4, partition coefficient: -0.85
Compound 4: middle estimate off by 0.04 log units, on the low side; the measured number falls inside the stated range.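

In this assay the change of methyl in place of hydrogen on an aromatic nitrogen now gives a number 0.34 log units lower from compound 3 to compound 4 (beyond the scatter) and, on another core, a number 0.38 log units lower from compound 2 to compound 1 (beyond the scatter); both steps run in the same direction, and each is modest and beyond the scatter. The change therefore carried over from the core of compound 2 to the core of compound 3, even though the site in compound 4 is meta to a methoxy group, but two pairs in one assay do not show that it will hold on further cores in the series. Nothing available here bears on what sets the direction or size of this step.

Among the compounds shown, the aromatic nitrogen carries only hydrogen or methyl, so it remains open whether an ethyl group, a longer chain or a chain ending in an amine or a carboxylic acid would shift the read-out in the same direction. Also open, on these data alone, is whether the step persists on a core without the methyl group that compound 3 and compound 4 share.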